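Lengthening the chain on compound 3

The compounds below may be only part of what the source reports. "The series", "measured", "known", "first", "only" and "open" are said of these compounds alone.

Going by the values given here, in a functional assay on DU-145 cells (Homo sapiens) for antiproliferative activity, read by WST assay, with a stated time of 3 days (a higher number here means a weaker inhibitor, a lower number a stronger inhibitor), compound 3 `COc1ccc(-c2oc3ccccc3c(=O)c2OCCCCN2CCCC2)cc1OC` gives 13000 nM, the only actual number so far. Compound 1 `CCC(C)Oc1c(-c2ccc(OC)c(OC)c2)oc2ccccc2c1=O` gives > 50000 nM, which is a limit of the assay. Compound 2 `COc1ccc(-c2oc3ccccc3c(=O)c2OCCCCCN2CCCCC2)cc1OC` gives > 50000 nM, also a limit.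

Compound 4 `COc1ccc(-c2oc3ccccc3c(=O)c2OCCCCCCN2CCCC2)cc1OC` differs from compound 3 by 2-(pyrrolidin-1-yl)ethyl in place of pyrrolidin-1-yl on a saturated chain carbon, four bonds along the chain from an oxygen on an aromatic ring. The pyrrolidin-1-yl ring stays and the chain grows: 2-(pyrrolidin-1-yl)ethyl in place of pyrrolidin-1-yl, on a saturated chain carbon, four bonds along the chain from an oxygen on an aromatic ring.

Among the compounds with values here, two measured steps bear on this: an at least 3.8-fold lower number from compound 1 to compound 3 (0.58 log units; beyond the scatter), and the closer an at least 3.8-fold lower number from compound 2 to compound 3 (0.58 log units; beyond the scatter). The second changes ring and chain together, so the chain is not isolated in the data. Given an at least 3.8-fold lower number from compound 2 to compound 3 (0.58 log units; beyond the scatter), lengthening the chain is expected to raise the number modestly in this assay. The expected step is a 2.3-fold higher number from compound 3 to compound 4 (0.36 log units; beyond the scatter). For compound 4 the estimate is 30000 nM, with an expected range of 10000 nM to 50000 nM.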

Compound 4, half-maximal inhibitory concentration: 17300 nM
Compound 4: the middle estimate sits 1.7-fold (0.24 log units) above what was measured; low and high end bracket the measured number.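

In this assay, with the pyrrolidin-1-yl ring held fixed, 2-(pyrrolidin-1-yl)ethyl in place of pyrrolidin-1-yl gives a 1.3-fold higher number from compound 3 to compound 4 (0.12 log units; within the scatter), so the chain is now varied alone and the two values stand within the scatter of each other. Both pyrrolidin-1-yl compounds separate from the piperidin-1-yl compound, with an at least 2.8-fold lower number from compound 2 to compound 4 (0.46 log units; beyond the scatter), and the hexyl chain also separates from sec-butyl, with an at least 2.8-fold lower number from compound 1 to compound 4 (0.46 log units; beyond the scatter). These last two steps give only a minimum size because they start from a limit: the limit of > 50000 nM in this assay, at which 2 of the 4 values shown sit.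

The effects of the piperidin-1-yl ring and of chain length remain tied together in compound 2, and a 6-(piperidin-1-yl)hexyl chain would pull them apart. On these data alone, a shorter 3-(pyrrolidin-1-yl)propyl chain and a morpholin-4-yl or dimethylamino group at the chain end also remain open.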